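This account rests on a few compounds, and the source may have more. Where it says the series, first, only, none or still open, it means among the compounds named here.

Measured in a functional assay on the whole organism with Mus musculus as the target, in the rotarod test; on this read-out higher numbers stand for an effect only at larger amounts of compound and lower numbers for an effect already at smaller amounts:
compound 1 `O=C(/C=C1\CCc2ccccc21)NC1CC1`: 235 mg/kg
compound 2 `CC(C)NC(=O)/C=C1\CCc2ccc(F)cc21`: > 100 mg/kg
compound 3 `CC(C)NC(=O)/C=C1\CCc2c(F)cc(F)cc21`: 76 mg/kg

Compound 2 stands only at > 100 mg/kg, which is a limit and not a number. It is the limit of > 100 mg/kg in this assay, at which 1 of the 3 values shown sits.

Compound 4 `O=C(/C=C1\CCc2ccc(F)cc21)NC1CC1` is not yet measured. Its difference from compound 2 is cyclopropyl in place of isopropyl on an amide-type nitrogen. Within the data shown here, the one measured step, an at least 1.3-fold lower number from compound 2 to compound 3 (0.11 log units; that floor lies within the scatter), is a different change, fluoro in place of hydrogen on an aromatic carbon, so it bears only indirectly. Compound 1, which also has cyclopropyl on the amide-type nitrogen, gives 235 mg/kg. On this basis, the expected step in this assay is a step that the limit leaves unreadable from compound 2 to compound 4, with nothing expected beyond the scatter. For compound 4 the estimated value is 150 mg/kg, with an expected range of 70 mg/kg to 320 mg/kg.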

Compound 4, dose for half-maximal effect: 62 mg/kg
Compound 4: middle estimate off by 2.4-fold (0.38 log units), on the high side; the whole stated range lies above it.
By their numbers in this assay, from the lowest: compounds 4 and 3 (each within the scatter of the next); then compound 1.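

In this assay, fluoro in place of hydrogen on an aromatic carbon now gives a step beyond the scatter: a 3.8-fold lower number from compound 1 to compound 4 (0.58 log units; beyond the scatter). Cyclopropyl in place of isopropyl on an amide-type nitrogen gives an at least 1.6-fold lower number from compound 2 to compound 4 (0.20 log units; that floor lies within the scatter), a floor set by a limit and not a measured size. The fluoro change now stands on two cores: the same change on two cores in this assay, an at least 1.3-fold lower number (0.11 log units; that floor lies within the scatter) from compound 2 to compound 3 and a 3.8-fold lower number (0.58 log units; beyond the scatter) from compound 1 to compound 4; the limit leaves it open whether they differ

As far as these compounds go, how a cyclobutyl group or a longer chain on the amide-type nitrogen would read here remains open. So does chloro in place of fluoro on the aromatic carbon.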